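Changing the aryl group on the amide nitrogen

This account rests on a few compounds, and the source may have more. Where it says the series, first, only, none or still open, it means among the compounds named here.

Compound 1 `O=C(COc1ccc2cc(/C=C3/SC(=O)NC3=O)ccc2c1)Nc1ccc(Br)cc1`: 10100 nM
Compound 2 `O=C(COc1ccc2cc(/C=C3/SC(=O)NC3=O)ccc2c1)Nc1c(F)cc(F)cc1Br`: 10400 nM

In a functional assay on HeLa cells (Homo sapiens) for cytotoxicity, with a stated time of 20 h (a higher number here means that more compound is tolerated, a lower number that less compound is tolerated), compound 1 gives 10100 nM and compound 2 gives 10400 nM. For the measured compounds named here, compound 2 holds the highest of the two numbers so far, but its nearest neighbour is compound 1, and the step of a 1.0-fold higher number from compound 1 to compound 2 (0.01 log units; within the scatter) is within the scatter, so the two cannot be ordered. Compound 3 `Cc1cc(Br)ccc1NC(=O)COc1ccc2cc(/C=C3/SC(=O)NC3=O)ccc2c1` is the third member of this series and differs from compound 2 only on the amide-type nitrogen: 4-bromo-2-methylphenyl in place of 2-bromo-4,6-difluorophenyl on an amide-type nitrogen. Going by the values given here, the only measured step that bears on this change is a 1.0-fold higher number from compound 1 to compound 2 (0.01 log units; within the scatter), where a different aryl group on the same nitrogen left the number essentially unchanged. On that basis no step beyond the scatter is expected for compound 3 in this assay, and the expected step of a 1.0-fold lower number from compound 2 to compound 3 (0.02 log units; within the scatter) is estimated to be flat. Compound 3 is therefore expected to give about 10000 nM, within a range of 5000 nM to 20000 nM.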

Compound 3, half-maximal cytotoxic concentration: 9900 nM
Compound 3: the middle estimate sits 1.0-fold (0.00 log units) above what was measured; measured number inside the range.
By their numbers in this assay, from the lowest: compounds 3, 1 and 2 (each within the scatter of the next).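

In this assay, a third aryl group on the amide-type nitrogen, 4-bromo-2-methylphenyl, again leaves the result flat, with a 1.1-fold lower number from compound 2 to compound 3 (0.02 log units; within the scatter). For the compounds shown here, compound 3 also gives the first single-group comparison at this position, methyl in place of hydrogen on an aromatic carbon, and the result is a 1.0-fold lower number from compound 1 to compound 3 (0.01 log units; within the scatter), so the three aryl groups cannot be ordered. Nothing available accounts for this agreement among the three compounds.

All three aryl groups carry bromine, so the compounds leave open whether the number would hold with an amine or a carboxylic acid on that ring in its place. They also leave open whether a longer chain in place of the methyl would give a step beyond the scatter.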